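This account rests on a few compounds, and the source may have more. Where it says the series, first, only, none or still open, it means among the compounds named here.

In a functional assay on KB cells (Homo sapiens) for cytotoxicity, read by resazurin assay, with a stated time of 3 days (a lower number here means a stronger inhibitor, a higher number a weaker inhibitor), compound 3 (`CCCCCC(=O)OCC(C)(C)CC1=C(O)C(=O)c2ccccc2C1=O`) gives 41000 nM, level within the scatter with compound 1 (`CCCCCC(=O)NCC(C)(C)CC1=C(O)C(=O)c2ccccc2C1=O`), which gives 40200 nM. Compound 2 (`CCCCCCCCCCCCCCCCCC(=O)NCC(C)(C)CC1=C(O)C(=O)c2ccccc2C1=O`) stands clearly lower at 6350 nM. Compound 4 (`CCCCCCCCCCCC(=O)OCC(C)(C)CC1=C(O)C(=O)c2ccccc2C1=O`) differs from compound 3 by hexyl in place of hydrogen on a saturated chain carbon, five bonds along the chain from a carbonyl carbon. For the measured compounds named here, the closest precedent is a 6.3-fold lower number from compound 1 to compound 2 (0.80 log units; beyond the scatter), which comes from dodecyl in place of hydrogen at that same place, a larger addition than hexyl. The step of a 1.0-fold higher number from compound 1 to compound 3 (0.01 log units; within the scatter), with (pentylcarbonyl)oxy in place of (pentylcarbonyl)amino, gives no reason to think that the earlier gain would fail to carry over. A smaller move towards lower numbers is therefore expected in this assay, an estimated 2.7-fold lower number from compound 3 to compound 4 (0.44 log units; beyond the scatter). Compound 4 is expected at 15000 nM, with an estimated range of 6000 nM to 35000 nM.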

Compound 4, half-maximal inhibitory concentration: 35700 nM
Compound 4: the middle estimate sits 2.4-fold (0.38 log units) below what was measured; the measured number lies above the stated range.
By their numbers in this assay, from the lowest: compound 2; then compounds 4, 1 and 3 (each within the scatter of the next).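

In this assay the ester chain shows no gain from hexyl in place of hydrogen at this position, with a 1.1-fold lower number from compound 3 to compound 4 (0.06 log units; within the scatter) for this change and a 6.3-fold lower number from compound 1 to compound 2 (0.80 log units; beyond the scatter) for dodecyl on the amide chain. Adding carbons at this place therefore does not lower the number in every case, and compound 4 goes against any such pattern. Nothing available explains this result. The compounds shown leave open whether the contrast follows the length of the added chain or the ester in place of the amide. A longer chain on the ester, such as dodecyl at this same place, would separate the two.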